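Methyl-to-ethyl change on the aromatic nitrogen substituent

The compounds below may be only part of what the source reports. "The series", "measured", "known", "first", "only" and "open" are said of these compounds alone.

Within the data shown here, compound 3 `Cn1ccc2cc(-c3ccc4oc(NC5CCCCC5)nc4c3)ccc21` is the only member of the series with a number in an assay on HEK293 cells for inhibition of Fatty-acid amide hydrolase 1 (Homo sapiens), read by fluorescence (a lower number here means a stronger inhibitor, a higher number a weaker inhibitor), where compound 3 gives 911 nM. Compound 1 `NC(=O)c1cccc(-c2ccc3oc(NC4CCCCC4)nc3c2)c1` reaches only a limit, > 1000 nM. Compound 2 `c1ccc(-c2ccc3oc(NC4CCCCC4)nc3c2)cc1` likewise sits at a limit, > 1000 nM. Among the measured compounds shown here, the one measured step, a step that the two limits leave unreadable from compound 1 to compound 2, cannot be read because both ends sit at the limit of > 1000 nM in this assay, at which 2 of the 3 values shown sit.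

Compound 4 `CCn1ccc2cc(-c3ccc4oc(NC5CCCCC5)nc4c3)ccc21` differs from compound 3 by methyl in place of hydrogen on a saturated chain carbon bound to an aromatic nitrogen; cut one bond further out, the change reads methyl to ethyl. For the measured compounds named here, no measured step touches this position, so nothing sets its size. For compound 4 a step of a 1.0-fold lower number from compound 3 to compound 4 (0.01 log units; within the scatter) is expected, that is none beyond the scatter. Compound 4 is therefore estimated at 900 nM, with a range from 400 nM to 2000 nM.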

Compound 4, half-maximal inhibitory concentration: 207 nM
The estimate for compound 4 lay 4.3-fold (0.64 log units) above the measured number, outside the stated range (below it).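

In this assay, methyl in place of hydrogen on a saturated chain carbon bound to an aromatic nitrogen gives a 4.4-fold lower number from compound 3 to compound 4 (0.64 log units; beyond the scatter). Among these compounds, this is the first readable step, and it shows that the number responds to the change from methyl to ethyl at this position. The earlier step cannot be read: the limit of > 1000 nM in this assay, at which 2 of the 4 values shown sit.

The compounds shown leave open whether propyl or a longer chain here lowers the number further or reverses the step. Also open, from the compounds shown here alone, is how an amine or a carboxylic acid at the end of this chain would read.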